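The compounds below may be only part of what the source reports. "The series", "measured", "known", "first", "only" and "open" are said of these compounds alone.

Measured so far in a functional assay on the whole organism (blood, strain Charles Foster/Wistar albino) with Rattus norvegicus as the target, with a stated time of 30 min, at a dose of 100 mg/kg by the oral route; a lower number here means less inhibition, a higher number more inhibition at the dose given (going by the name of the read-out):
compound 1 `COc1ccc(-c2cc(-c3ccccc3)no2)c(OCCCN2CCCC2)c1`: 21.2%
compound 2 `CCOC(=O)COc1cc(OC)ccc1-c1cc(-c2ccccc2)no1`: 10.4%

Compound 2 stands lowest of the two numbers in this assay; compound 1 is the nearest and only other point. Within the data shown here, the one measured step is a number 10.8 percentage points lower from compound 1 to compound 2 (beyond the scatter), where ethoxycarbonyl replaced 2-(pyrrolidin-1-yl)ethyl on a saturated chain carbon bound to an oxygen on an aromatic ring, a modest drop beyond the scatter.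

Compound 3 `CCN(CC)CC(O)COc1cc(OC)ccc1-c1cc(-c2ccccc2)no1` differs from compound 2 by 2-(diethylamino)-1-hydroxyethyl in place of ethoxycarbonyl on a saturated chain carbon bound to an oxygen on an aromatic ring. This change loosely mirrors the reverse of the measured step: the ethoxycarbonyl that entered there now leaves, and the entering group again contains nitrogen, here together with a hydroxyl. Among the measured compounds shown here, only that one step bears on it, so the expected step for compound 3 is a number 9.6 percentage points higher from compound 2 to compound 3 (within the scatter), a modest rise of roughly the size seen before, with wide uncertainty since no measured compound carries a hydroxyl. Compound 3 is therefore expected to give 20% in this assay, within 8% to 32%.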

Compound 3, a percentage reported as inhibition, in the whole organism at one dose (the size of the read-out at that dose, not a potency): 13.8%
Compound 3: the middle estimate sits 6.2 percentage points above what was measured; low and high end bracket the measured number.
By their numbers in this assay, from the lowest: compounds 2, 3 and 1 (each within the scatter of the next, the first and the last beyond it).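

In this assay, 2-(diethylamino)-1-hydroxyethyl in place of ethoxycarbonyl on a saturated chain carbon bound to an oxygen on an aromatic ring gives a number 3.4 percentage points higher from compound 2 to compound 3 (within the scatter), so this nitrogen-bearing chain with its hydroxyl cannot be told apart from the ester. The same group in place of 2-(pyrrolidin-1-yl)ethyl gives a number 7.4 percentage points lower from compound 1 to compound 3 (within the scatter), so these two amine chains cannot be told apart either, and the one gap beyond the scatter, between the other two compounds, is now bridged by a compound within the scatter of both. Nothing available explains these numbers.

Open is how the hydroxyl and the diethylamino part each count at this place, as the compounds shown carry them only together. Also open, as far as these compounds go, is how a carboxylic acid in place of ethoxycarbonyl, or a morpholine at the end of the chain, would read here.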